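From trifluoromethyl to fluoro on compound 1

This account rests on a few compounds, and the source may have more. Where it says the series, first, only, none or still open, it means among the compounds named here.

Compound 1 `CCC(c1nc2ncc(Cl)cc2[nH]1)[C@H]1CC[C@@H](c2ccnc3ccc(C(F)(F)F)cc32)CC1` is the starting point here. In an ADME assay on microsomes from liver (Rattus norvegicus) for metabolic stability, with a stated time of 10 min, tested at 0.5 uM (a higher number here means that more of the compound is left, a lower number that less of the compound is left), compound 1 gives 81% as its reading. Two further compounds give context: compound 2 `CCC(Nc1nnc(-c2ccc(OC)cc2)o1)[C@H]1CC[C@H](Oc2ccnc3ccccc23)CC1` reads 88% in this assay and compound 3 `CCC(c1nc2ccc(Cl)cc2[nH]1)[C@H]1CC[C@H](Oc2ccnc3ccccc23)CC1` reads 80% in the same measurement. All three numbers lie within the usual scatter of one another, so compound 1 stands level with the other two and they cannot be ranked.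

Compound 4 `CCC(c1nc2ncc(Cl)cc2[nH]1)[C@H]1CC[C@@H](c2ccnc3ccc(F)cc32)CC1` has not been measured yet. It keeps the core of compound 1 but carries fluoro in place of trifluoromethyl on an aromatic carbon of a six-membered aromatic ring of carbon only. Among the measured compounds shown here, no two measured compounds differ in just one place, so there is no direct measure of such a swap. Still, compound 1 at 81% and compound 3 at 80% differ in more than one place and stay within the scatter, which leads to an expectation of no step beyond the scatter in this assay for this single change. The estimated step of a number 3 percentage points lower from compound 1 to compound 4 (within the scatter) points slightly downward and stays inside the usual scatter. For compound 4 the expected reading is 78% with an estimated range from 66% to 90% across repeat measurements.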

Compound 4, percent of the compound remaining: 35%
The estimate for compound 4 lay 43 percentage points above the measured number; the measured number lies below the stated range.
By their numbers in this assay, from the lowest: compound 4; then compounds 3, 1 and 2 (each within the scatter of the next).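

Among the compounds shown here, this is the first direct reading of a single change in these compounds: in this assay the swap of trifluoromethyl for fluoro on an aromatic carbon gives a number 46 percentage points lower from compound 1 to compound 4 (beyond the scatter) while the rest of the core of compound 1 stays the same. This position is therefore not one where these two groups can be exchanged freely, since the group on this one carbon is enough to move the read-out far beyond the usual scatter. Nothing in the data at hand explains why the number falls so far, so the step stands as an observation without a stated cause.

The compounds shown leave open whether a plain hydrogen, a methyl, a methoxy or a nitrile on this aromatic carbon would read closer to compound 1 or closer to compound 4. They also leave open whether the same swap would give a step of similar size on a different core; compound 2 and compound 3 each differ from compound 1 in more than one place and cannot answer this.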